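Carboxy added at the amine-bearing carbon of compound 3

This account rests on a few compounds, and the source may have more. Where it says the series, first, only, none or still open, it means among the compounds named here.

Measured so far:
compound 1 `CCCCCCCCCCCCN(CCCCCCCCCCCC)[C@H](CCC(=O)NC(CCCC(N)C(=O)O)C(=O)O)C(=O)O` gives 0.0015 nM
compound 2 `CCCCCCCCCCCNC(=O)[C@H](N)CCC(=O)NC(CCCC(N)C(=O)O)C(=O)O` gives 0.826 nM
compound 3 `CCCCCCCCCCCC(=O)N[C@H](CCC(=O)NCCCCCN)C(=O)O` gives > 100 nM

All three were run in a functional assay on HEK293 cells for agonist activity at Nucleotide-binding oligomerization domain-containing protein 1 (Homo sapiens), read by spectrophotometry; on this read-out lower numbers stand for an effect already at smaller amounts and higher numbers for an effect only at larger amounts of compound. Compound 1 and compound 2 return numbers. Compound 3 does not: for compound 3 the result is a limit, (the limit of > 100 nM in this assay, at which 1 of the 3 values shown sits), so only its position at the edge of the measured range is known. Compound 3 carries a plain terminal amine at the end of its chain, whereas compound 1 and compound 2 both end in a diacid bearing an amine.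

Compound 4 `CCCCCCCCCCCC(=O)N[C@H](CCC(=O)NCCCC[C@H](N)C(=O)O)C(=O)O` is not yet measured. It differs from compound 3 by carboxy in place of hydrogen on a saturated chain carbon bound to an amine nitrogen and a saturated chain carbon. This restores an amino acid terminus of the kind present in compound 2, which gives a low value in this assay.

Compound 4 is expected to give a number rather than a limit, with the step of an at least 5.0-fold lower number from compound 3 to compound 4 (0.69 log units; beyond the scatter) going toward lower values, beyond the usual scatter. The estimate for compound 4 is 20 nM, with a range from 2 nM to 200 nM.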

Compound 4, half-maximal effective concentration: 0.96 nM
The estimate for compound 4 lay 21-fold (1.32 log units) above the measured number; measured number below the stated range.
By their numbers in this assay, from the lowest: compound 1; then compounds 2 and 4 (each within the scatter of the next). At a limit, above all of these: compound 3.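

Carboxy in place of hydrogen on a saturated chain carbon bound to an amine nitrogen and a saturated chain carbon, read as 3-aminopropyl to 3-amino-3-carboxypropyl, gives an at least 100-fold lower number from compound 3 to compound 4 (2.01 log units; beyond the scatter) in this assay. This is the first comparison in the series that isolates a single place, so this carbon of the chain end is now shown to matter to the read-out. Compound 3 stands at a limit, so the step gives only a bound and not its full size: the limit of > 100 nM in this assay, at which 1 of the 4 values shown sits.

The compounds shown leave open whether a carboxylic acid is specifically required at this carbon, or whether a methyl ester or a primary carboxamide would serve there. Also open, on these data alone, are the role of the amine on this carbon and how a longer chain would read.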